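The source may hold more compounds than are shown below. What is called first, only, known or untested is meant among the compounds shown, and "the series" means these compounds.

Measured compounds:
compound 1 `CN(C)C(=O)c1cccc(C#Cc2cc(Cl)ccc2OCC(=O)O)c1`, in an assay on CHO cells for displacement of a labelled ligand from prostaglandin D2 receptor 2 (Homo sapiens), read by scintillation counting (a higher number here means a weaker inhibitor, a lower number a stronger inhibitor), compound 1 gives 52 nM
compound 2 `CN(c1cccc(C#Cc2cc(Cl)ccc2OCC(=O)O)c1)S(C)(=O)=O`, compound 2 gives 122 nM
compound 3 `COc1ccc(-c2ccc(C#Cc3cc(Cl)ccc3OCC(=O)O)cc2S(C)(=O)=O)cc1`, compound 3 gives 7 nM

Compound 3 stands at the lowest number of the three in this assay, well separated from compound 1 and from compound 2. Compound 4 `CS(=O)(=O)c1cccc(C#Cc2cc(Cl)ccc2OCC(=O)O)c1` arises from compound 3 by the change (hydrogen in place of 4-methoxyphenyl on an aromatic carbon). For the measured compounds named here, no measured step removes such a group; the only measured step, a 2.3-fold higher number from compound 1 to compound 2 (0.37 log units; beyond the scatter), swaps one small group for another on a similar scaffold and bears on it only indirectly. Compounds 1 and 2, which also lack the biaryl, give numbers far above compound 3, so compound 4 is expected to show a clearly higher number, by roughly an 11-fold higher number from compound 3 to compound 4 (1.06 log units; beyond the scatter). Compound 4 is therefore estimated at 80 nM, in the range 30 nM to 250 nM.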

Compound 4, inhibition constant: 15 nM
Compound 4: the middle estimate sits 5.3-fold (0.73 log units) above what was measured, outside the stated range (below it).
By their numbers in this assay, from the lowest: compound 3; then compound 4; then compound 1; then compound 2.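

In this assay, taking away the 4-methoxyphenyl gives only a modest loss, a 2.1-fold higher number from compound 3 to compound 4 (0.33 log units; beyond the scatter), so most of the binding seen in compound 3 does not depend on that group. The methylsulfonyl group alone also reads better than either small group it replaces, with a 3.5-fold lower number from compound 1 to compound 4 (0.54 log units; beyond the scatter) and an 8.1-fold lower number from compound 2 to compound 4 (0.91 log units; beyond the scatter). No measured evidence accounts for these steps. The compounds shown leave open how a plain phenyl without the methoxy, or an amine, would read on that aromatic carbon. They also leave open whether a sulfonamide could stand in for the methylsulfonyl.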